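A few compounds are considered here, and "the series" means these few. Any claim that something is new, unique, unknown or untested is made for them only; others in the source may bear on it.

Working notes on the series. The shared core carries a thioether-linked acid chain and a variable aromatic group; compound 1 `CCCCC(Sc1nc(Cl)cc(Nc2nc(-c3ccc(Cl)cc3)cs2)n1)C(=O)O`, compound 2 `CCCCCCC(Sc1nc(Cl)cc(Nc2nc(-c3cccc4ccccc34)cs2)n1)C(=O)O` and compound 3 `CCCCCCC(Sc1nc(Cl)cc(Nc2nc(-c3ccc(F)cc3F)cs2)n1)C(=O)O` have been measured in an assay for inhibition of Polyunsaturated fatty acid 5-lipoxygenase (Homo sapiens), read by HPLC, with stated times of 15 min and 10 min; a lower number here means a stronger inhibitor, a higher number a weaker inhibitor. Compound 1 gives 900 nM, compound 2 gives 400 nM and compound 3 gives 1500 nM. Compound 3 thus stands at the highest of the three numbers; its gap to compound 1 lies within the scatter, while the step of a 3.8-fold higher number from compound 2 to compound 3 (0.57 log units; beyond the scatter) lies beyond it. Compound 4 `CCCCCCC(Sc1nc(Cl)cc(Nc2nc(-c3ccc(-c4ccccc4)cc3)cs2)n1)C(=O)O` has not yet been measured. Its change from compound 3 is 4-phenylphenyl in place of 2,4-difluorophenyl on an aromatic carbon. For the measured compounds named here, the only step that bears directly on this place is a 3.8-fold higher number from compound 2 to compound 3 (0.57 log units; beyond the scatter), where a larger two-ring aromatic group stood against the difluorinated phenyl. As 4-phenylphenyl brings two aromatic rings into the same place, a step of similar size in the opposite direction is expected, a 3.0-fold lower number from compound 3 to compound 4 (0.48 log units; beyond the scatter), with a number closer to that of compound 2 than to that of compound 3. Compound 4 is therefore estimated at 500 nM, within a range from 150 nM to 2000 nM.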

Compound 4, half-maximal inhibitory concentration: 300 nM
Compound 4: the middle estimate sits 1.7-fold (0.22 log units) above what was measured; low and high end bracket the measured number.
By their numbers in this assay, from the lowest: compounds 4 and 2 (each within the scatter of the next); then compounds 1 and 3 (each within the scatter of the next).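

At this place, on an aromatic carbon of a five-membered aromatic ring with 1 nitrogen and 1 sulfur, the change to 4-phenylphenyl in this assay gives a 5.0-fold lower number from compound 3 to compound 4 (0.70 log units; beyond the scatter), so a second group with 2 six-membered aromatic rings of carbon only, after naphthalen-1-yl, stands apart from 2,4-difluorophenyl. The two groups with two rings do not separate, with a 1.3-fold lower number from compound 2 to compound 4 (0.12 log units; within the scatter), so this assay gives no ranking between naphthalen-1-yl and 4-phenylphenyl. Nothing available bears on the origin of these steps.

The compounds shown leave open whether the lower numbers follow the second ring or the absence of the two fluorine atoms, a question that plain phenyl at this place would address. Also open, going by these compounds, is how an amine or a hydroxyl group on the outer ring of 4-phenylphenyl would read.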